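This account rests on a few compounds, and the source may have more. Where it says the series, first, only, none or still open, it means among the compounds named here.

Working notes on the dithiocarbamate series bearing the shared amide core.

Compound 1 `CC1CCCCN1C(=S)SCc1ccc(C(=O)Nc2ccccc2N)cc1` gives 86.9% in a functional assay on MGC-803 cells (Homo sapiens) for antiproliferative activity, read by CCK-8 assay, with a stated time of 72 h, tested at 8 uM; on this read-out higher numbers stand for a stronger effect at the one concentration tested and lower numbers for a weaker effect. Compound 2 `CN(Cc1cccnc1)C(=S)SCc1ccc(C(=O)Nc2ccccc2N)cc1` gives 85.5%; the change a number 1.4 percentage points lower from compound 1 to compound 2 (within the scatter) replaces the whole amine on the thiocarbonyl carbon and leaves the read-out where it was. Compound 3 `Nc1ccccc1NC(=O)c1ccc(CSC(=S)N2CCN(c3ccc(F)cc3)CC2)cc1` gives 48.7%, the lowest of the three numbers: compound 2 stands higher and compound 1 stands higher still, both beyond the scatter.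

Compound 4 `CN1CCN(C(=S)SCc2ccc(C(=O)Nc3ccccc3N)cc2)CC1` differs from compound 3 in one place: methyl in place of 4-fluorophenyl on an amine nitrogen in a ring. For the measured compounds named here, no measured step touches this position; the only step on record, from compound 1 to compound 2, swaps one small amine for another and is within the scatter, so it gives no size for this change. What the numbers do show is that compound 3, which carries the 4-fluorophenyl, sits far below compounds 1 and 2, which carry smaller groups on the thiocarbonyl nitrogen. On that ground a rise is expected for compound 4, estimated as a number 21.3 percentage points higher from compound 3 to compound 4 (beyond the scatter) in this assay. Compound 4 is therefore expected to give about 70%, in the range 45% to 90%.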

Compound 4, a percentage reported as inhibition, at one concentration (the size of the read-out at that concentration, not a potency): 84.4%
For compound 4 the middle estimate is 14.4 percentage points below the measured one, and the stated range covers the measured number.
By their numbers in this assay, from the lowest: compound 3; then compounds 4, 2 and 1 (each within the scatter of the next).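

For the compounds shown here, at the amine nitrogen in the ring, methyl in place of 4-fluorophenyl gives a number 35.7 percentage points higher from compound 3 to compound 4 (beyond the scatter) in this assay, which puts a first size on a change at this position and shows that the ring with methyl does not share the low number of compound 3. With 4-methylpiperazin-1-yl on the thiocarbonyl carbon, the read-out stays level with the other two amines: a number 1.1 percentage points lower from compound 2 to compound 4 (within the scatter) and a number 2.5 percentage points lower from compound 1 to compound 4 (within the scatter). No measurement at hand offers a reason for the large step at this nitrogen.

On these data alone, only 4-fluorophenyl and methyl stand at this nitrogen, so it remains open whether the lower number follows the aromatic ring or the fluorine. Unsubstituted phenyl, benzyl or a longer chain such as propyl at the same nitrogen also remains open.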